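A few compounds are considered here, and "the series" means these few. Any claim that something is new, unique, unknown or untested is made for them only; others in the source may bear on it.

Of the compounds shown here, three from the same series have been measured in a physicochemical assay for solubility, read by HPLC, using the shake flask method, measured as kinetic solubility, with a stated time of 2 h, at pH 7.4; on this read-out higher numbers stand for higher solubility and lower numbers for lower solubility. Compound 1, with the structure `Cc1ccc(-c2cnn3c(NCc4ccccn4)cc(C)nc23)cc1`, gives < 5000 nM in this assay, which is a limit of the measurement rather than a number. Compound 2, `Cc1cc(NCc2ccc(F)cn2)n2nc(C)c(-c3ccccc3)c2n1`, gives < 5000 nM in this assay, again a limit. Compound 3, `Cc1cc(NCc2cccc[n+]2[O-])n2ncc(-c3ccccc3)c2n1`, gives 159000 nM in this assay. Compound 1 therefore stands at the low end of what the assay can resolve, and it shares that position with compound 2, as shown by the limit of < 5000 nM in this assay, at which 2 of the 3 values shown sit; only compound 3 returns a numerical value above that floor.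

The unmeasured compound 4, `Cc1cc(NCc2ccccn2)n2ncc(-c3ccc(F)cc3C)c2n1`, differs from compound 1 in a single place: 4-fluoro-2-methylphenyl in place of 4-methylphenyl on an aromatic carbon. Going by the values given here, no measured pair in this set shows what such a swap does to solubility, so the size of the step cannot be read from the data. Since the group that leaves and the group that enters carry the same count of donors and acceptors and no charge, the expected step from compound 1 to compound 4 is a step that the limit leaves unreadable from compound 1 to compound 4, none beyond the scatter. Compound 4 is accordingly expected to give about 3000 nM in this assay, within a range of 500 nM to 12000 nM, most likely reported again as a limit.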

Compound 4, solubility: 42300 nM
The estimate for compound 4 lay 14-fold (1.15 log units) below the measured number; measured number above the stated range.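

Exchanging 4-methylphenyl for 4-fluoro-2-methylphenyl on the aromatic carbon two ring bonds from the ring nitrogen gives an at least 8.4-fold higher number from compound 1 to compound 4 (0.92 log units; beyond the scatter) in this assay. Going by these compounds alone, this is the first single change that can be read, and it shows that the group at this position can move the read-out beyond the scatter even though the count of donors and acceptors stays the same and neither group carries a charge. The true size of the step remains unknown, as compound 1 gives only a limit: the limit of < 5000 nM in this assay, at which 2 of the 4 values shown sit.

The entering group differs from the leaving one in two ways, so the compounds shown leave open whether the fluorine, the added methyl or the two together account for the step, a question that 4-fluorophenyl and 2-methylphenyl at this position would separate. Also open, on these data alone, is how far the read-out would move with an amine or a carboxylic acid on this phenyl ring, and whether the same exchange would give a similar step on a core carrying a different group at the other positions.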